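Replacing the aryl group on a sulfonamide nitrogen

A few compounds are considered here, and "the series" means these few. Any claim that something is new, unique, unknown or untested is made for them only; others in the source may bear on it.

In a functional assay on M21 cells (Homo sapiens) for antiproliferative activity, read by sulforhodamine B assay, with a stated time of 48 h (a higher number here means a weaker inhibitor, a lower number a stronger inhibitor), compound 2 (`O=C1NCCN1c1ccc(S(=O)(=O)Nc2ccc(Br)cc2)cc1`) gives 130 nM and compound 1 (`O=C1NCCN1c1ccc(S(=O)(=O)Nc2ccc(I)cc2)cc1`) gives 260 nM, two values within the scatter of each other. That measured step, a 2.0-fold lower number from compound 1 to compound 2 (0.30 log units; within the scatter), only exchanges one halogen for another. Compound 3 (`COc1ccccc1NS(=O)(=O)c1ccc(N2CCNC2=O)cc1`) changes the whole group: 2-methoxyphenyl in place of 4-bromophenyl on a sulfonamide nitrogen, with 2-methoxyphenyl in place of 4-bromophenyl on a sulfonamide nitrogen. For the measured compounds named here, no measured step covers this kind of change, so its direction stays open. The expected step is loosely estimated as a 2.3-fold higher number from compound 2 to compound 3 (0.36 log units; beyond the scatter). For compound 3 the estimated value is 300 nM, with an expected range from 60 nM to 2000 nM.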

Compound 3, half-maximal inhibitory concentration: 300 nM
Compound 3: middle estimate and measured number agree at the digits printed, within the range that was stated.
By their numbers in this assay, from the lowest: compounds 2, 1 and 3 (each within the scatter of the next, the first and the last beyond it).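

Putting 2-methoxyphenyl on the sulfonamide nitrogen in place of 4-bromophenyl gives a 2.3-fold higher number from compound 2 to compound 3 (0.36 log units; beyond the scatter) and in place of 4-iodophenyl gives a 1.2-fold higher number from compound 1 to compound 3 (0.06 log units; within the scatter) in this assay. So this position accepts an aromatic ring with no halogen at all, and the change of whole group moves the number only modestly. No measurement here bears on why. The compounds shown leave open whether a phenyl ring carrying an amine or a carboxylic acid would hold these numbers, and what a non-aromatic group such as cyclohexyl would give.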